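The source may hold more compounds than are shown below. What is called first, only, known or untested is meant among the compounds shown, and "the series" means these compounds.

Measured so far in a functional assay on the whole organism (stomach) with Rattus norvegicus as the target; on this read-out higher numbers stand for an effect only at larger amounts of compound and lower numbers for an effect already at smaller amounts:
compound 1, `CC(C)C/N=C(\S)NCCCCn1nc(-c2ccccc2)ccc1=O`: > 100 mg/kg (a limit of the assay)
compound 2, `C/N=C(/NC#N)NCCCCCn1nc(-c2ccccc2)cc(C)c1=O`: > 100 mg/kg (a limit of the assay)

For compound 1 only a limit is known: in this assay compound 1 gives > 100 mg/kg, which is a limit of the assay and not a number. Compound 2 likewise shows > 100 mg/kg in this assay, again a limit. Both values thus sit at the same point, namely (the limit of > 100 mg/kg in this assay, at which 2 of the 2 values shown sit).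

Compound 3, `C=CCNC(=S)NCCCCn1nc(-c2ccccc2)ccc1=O`, has not yet been measured. It differs from compound 1 in a single place: a group of 6 heavy atoms (4 carbon, 1 nitrogen, 1 sulfur; no ring) in place of a group of 7 heavy atoms (5 carbon, 1 nitrogen, 1 sulfur; no ring), on an amine nitrogen. For the measured compounds named here, no step between two measured compounds is available, so the expectation rests on the structural change alone. The step expected in this assay is a step that the limit leaves unreadable from compound 1 to compound 3, nothing beyond the usual scatter. Compound 3 is therefore estimated at 150 mg/kg, with a range from 50 mg/kg to 500 mg/kg, and most likely once more reported only as a limit.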

Compound 3, dose for half-maximal effect: > 100 mg/kg
Compound 3: a limit, no number; the forecaster's own chance of this, stated with the estimate: 80%; the middle value is on the limit's open side.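

No step can be read from compound 1 to compound 3 in this assay, since both values are limits and not numbers: the limit of > 100 mg/kg in this assay, at which 3 of the 3 values shown sit.

The compounds shown leave open what dose of any of them would give an effect, and whether swapping the group on the amine nitrogen changes that dose.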